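The source may report more compounds than this note shows. Statements on the series, on what has been measured and on what is new or still open speak of the compounds shown alone.

Measured so far in a functional assay on the whole organism (strain Sprague-Dawley) for inhibition, with Rattus norvegicus as the target; a lower number here means that less compound is needed, a higher number that more compound is needed for the effect:
Compound 1, `COc1cccc2cc(C(=O)O)cnc12`, gives 150 mg/kg.
Compound 2, `Cc1cccc2cc(C(=O)O)cnc12`, gives only a limit of the assay, > 25 mg/kg.
Compound 3, `COc1cccc2c(=O)c(-c3nn[nH]n3)c[nH]c12`, gives 0.312 mg/kg.

The change from compound 1 to compound 2 is methyl in place of methoxy on an aromatic carbon. Its size in this assay is a step that the limit leaves unreadable from compound 1 to compound 2, unreadable because of the limit of > 25 mg/kg in this assay, at which 1 of the 3 values shown sits. Compound 3 has the lowest number of the two readable values; how its core differs from the core of compound 1 is not broken down here.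

Compound 4, `Cc1cccc2c(=O)c(-c3nn[nH]n3)c[nH]c12`, has not yet been measured in this assay. It differs from compound 3 by methyl in place of methoxy on an aromatic carbon, the same change as that from compound 1 to compound 2, at the same kind of place. Since the earlier step is unreadable, the expectation for compound 4 rests on the value of compound 3, 0.312 mg/kg, and on the small size of the change. The step expected from compound 3 to compound 4 is a 1.9-fold higher number from compound 3 to compound 4 (0.28 log units; within the scatter). Compound 4 is estimated at 0.6 mg/kg, most likely between 0.15 mg/kg and 3 mg/kg.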

Compound 4, minimum effective dose: > 10 mg/kg
Compound 4: a limit, no number; the forecaster's own chance of this, stated with the estimate: 15%; at least 16-fold (1.22 log units) between middle value and limit.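

In this assay, going by these compounds alone, methyl in place of methoxy on an aromatic carbon of the core of compound 3 gives an at least 32-fold higher number from compound 3 to compound 4 (1.50 log units; beyond the scatter), a large step beyond the scatter, and compound 4 stands at a limit rather than a number: the limit of > 10 mg/kg in this assay, at which 1 of the 4 values shown sits. The same change on the core of compound 1 cannot be read, because compound 2 also stands at a limit rather than a number: the limit of > 25 mg/kg in this assay, at which 1 of the 4 values shown sits. The result therefore shows that this change is far from small on the core of compound 3, but it does not show whether a step of this size carries over to the core of compound 1, since only one readable pair exists.

On these data alone, how an ethoxy, a hydroxyl or an amine would read at this aromatic carbon stays open. As far as these compounds go, compound 1 and compound 3 differ in more than one place, so what separates their values also stays open.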